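A few compounds are considered here, and "the series" means these few. Any claim that something is new, unique, unknown or untested is made for them only; others in the source may bear on it.

In an ADME assay on HEK293 cells (Homo sapiens) for cytotoxicity, with a stated time of 72 h (a higher number here means that more compound is needed for the effect, a lower number that less compound is needed), compound 1 `Cc1cc(NC(=O)Nc2ccc(C(C)(C)C)cc2)c2ccccc2n1` carries tert-butyl and gives > 25000 nM as a limit, not a number. Compound 2 `CC(=O)c1ccc(NC(=O)Nc2cc(C)nc3ccccc23)cc1` carries acetyl at the same place and gives > 25000 nM as a limit too. Compound 3 `Cc1cc(NC(=O)Nc2ccc(N(C)C)cc2)c2ccccc2n1` carries dimethylamino there and stands at > 25000 nM as yet another limit, so it cannot be ranked against the other two. All three share one reading, the limit of > 25000 nM in this assay, at which 3 of the 3 values shown sit, and no exact number exists for any of them.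

Compound 4 `COC(=O)c1ccc(NC(=O)Nc2cc(C)nc3ccccc23)cc1` has not been measured. The move to it is methoxycarbonyl in place of dimethylamino on an aromatic carbon with methoxycarbonyl in place of dimethylamino on an aromatic carbon, para to a large group.

Three measured swaps at this place bear on the move: a step that the two limits leave unreadable from compound 1 to compound 2 and a step that the two limits leave unreadable from compound 1 to compound 3 and a step that the two limits leave unreadable from compound 2 to compound 3 give no size to build on. Compound 2 is the nearest guide, since its acetyl holds a carbonyl as methoxycarbonyl does, and it reads > 25000 nM as a limit.

No change beyond the usual scatter is therefore expected in this assay and the estimated step is a number no higher from compound 3 to compound 4 (the limit leaves the size open) in size. For compound 4 the estimate is 25000 nM with 12000 nM to 50000 nM as the expected range.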

Compound 4, half-maximal effective concentration: 15000 nM
Estimate against measurement, compound 4: 1.7-fold (0.22 log units) above; low and high end bracket the measured number.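

In this assay, among the compounds shown here, compound 4 gives 15000 nM, the first exact number for any group at this place on the ring, so this change yields a reading that the earlier compounds did not. Each comparison with compound 4 gives only a floor, not a full size: replacing dimethylamino with methoxycarbonyl gives an at least 1.6-fold lower number from compound 3 to compound 4 (0.22 log units; that floor lies within the scatter), replacing methyl with methoxy on the carbonyl carbon gives an at least 1.6-fold lower number from compound 2 to compound 4 (0.22 log units; that floor lies within the scatter), and replacing tert-butyl with methoxycarbonyl gives an at least 1.6-fold lower number from compound 1 to compound 4 (0.22 log units; that floor lies within the scatter). The steps among compound 1, compound 2 and compound 3 cannot be read, and all three floors start from one shared reading: the limit of > 25000 nM in this assay, at which 3 of the 4 values shown sit.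

On these data alone, the true size of each step therefore stays open, and so does whether the methoxycarbonyl group really separates compound 4 from the other three compounds by more than the usual scatter. As far as these compounds go, it also remains open whether a carboxylic acid, a primary amide or the longer ethoxycarbonyl group at this place would give an exact number, and how such a number would compare with that of compound 4.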